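This account rests on a few compounds, and the source may have more. Where it says the series, first, only, none or still open, it means among the compounds named here.

Measured so far:
compound 1 `COC(=O)c1cc(CC(C)CN2CC3CCCCC3C(C(=O)N3CCN(c4ccc([N+](=O)[O-])cc4)CC3)C2)cc(C(=O)OC)c1`, in an assay on isolated protein for binding affinity to somatostatin receptor type 1 (Homo sapiens) (a higher number here means weaker binding, a lower number tighter binding), 1000 nM
compound 2 `C[C@@H](Cc1ccc2ocnc2c1)CN1C[C@@H]2CCCC[C@@H]2[C@H](C(=O)N2CCN(c3ccc(F)c(F)c3)CC2)C1`, in this assay 1620 nM

Compound 2 sits alongside compound 1 in this assay: the two numbers lie within the usual scatter of each other, so nothing separates them. Within the data shown here, neither compound binds tightly, and no step between measured compounds in this set differs in only one place, so there is no measured step to lean on.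

Compound 3 `C[C@@H](Cc1ccc2ncnn2c1)CN1C[C@@H]2CCCC[C@@H]2[C@H](C(=O)N2CCN(c3ccc(F)c(F)c3)CC2)C1` is the next compound. It differs from compound 2 by a group of 9 heavy atoms (6 carbon, 3 nitrogen; one five-membered aromatic ring with 3 hetero atoms, one six-membered aromatic ring with 1 hetero atom) in place of a group of 9 heavy atoms (7 carbon, 1 nitrogen, 1 oxygen; one five-membered aromatic ring with 2 hetero atoms, one six-membered aromatic ring of carbon only), on a saturated chain carbon, three bonds along the chain from an amine nitrogen in a ring. The two groups that are exchanged have the same count of heavy atoms and both carry two fused aromatic rings; the change adds one hydrogen-bond acceptor.

With no measured step of this kind in the set, the expectation for compound 3 is a step of a 1.1-fold lower number from compound 2 to compound 3 (0.03 log units; within the scatter) in this assay, that is, none beyond the scatter. Compound 3 is accordingly estimated at 1500 nM, expected to fall between 600 nM and 4000 nM.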

Compound 3, dissociation constant: 9120 nM
Compound 3: middle estimate off by 6.1-fold (0.78 log units), on the low side; the whole stated range lies below it.
By their numbers in this assay, from the lowest: compounds 1 and 2 (each within the scatter of the next); then compound 3.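

Among these compounds, this is the only single-place step: in this assay it reads a 5.6-fold higher number from compound 2 to compound 3 (0.75 log units; beyond the scatter), beyond the scatter. The number at this position, on a saturated chain carbon, three bonds along the chain from an amine nitrogen in a ring, therefore depends on which fused aromatic pair sits there, even at the same heavy-atom count, whereas compound 1 and compound 2 differ in more than one place and could not show this. No measurement at hand accounts for the step.

A single exchange cannot separate the loss of 1,3-benzoxazol-5-yl oxygen from the gain in ring nitrogens or the added acceptor. On these data alone, how a plain phenyl, an indol-5-yl or a carboxylic acid would read at this place in this assay remains open.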